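This account rests on a few compounds, and the source may have more. Where it says the series, first, only, none or still open, it means among the compounds named here.

Compound 1 `O=[N+]([O-])c1ccc(-c2nc3cc(Cl)c(Cl)cc3[nH]2)cc1` gives 56000 nM in an ADME assay on MDBK cells (Bos taurus) for cytotoxicity, read by MTT assay, with a stated time of 96 h; a higher number here means that more compound is tolerated, a lower number that less compound is tolerated.
Compound 2 `Fc1cccc(F)c1-c1nc2cc(Cl)c(Cl)cc2[nH]1` gives 43000 nM in this assay.

Among these two, compound 1 holds the higher number, but its value and that of compound 2 lie within the usual scatter of this kind of measurement, so the two cannot be told apart. Going by the values given here, no pair of measured compounds differs in one place only, so no measured step exists to guide the next move. Compound 3 `Oc1ccc(-c2nc3cc(Cl)c(Cl)cc3[nH]2)cc1` has not yet been measured in this assay. It differs from compound 1 in one place: hydroxy in place of nitro on an aromatic carbon. Among the compounds with values here, with no single-change step available, the expectation rests on the two values alone, and the step of a 1.1-fold higher number from compound 1 to compound 3 (0.03 log units; within the scatter) is expected to be small and to stay within the scatter. Compound 3 is therefore estimated to give about 60000 nM in this assay, with a likely range from 20000 nM to 150000 nM.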

Compound 3, half-maximal cytotoxic concentration: 11000 nM
Compound 3: middle estimate off by 5.5-fold (0.74 log units), on the high side; measured number outside the range, below it.
By their numbers in this assay, from the lowest: compound 3; then compounds 2 and 1 (each within the scatter of the next).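

Going by these compounds alone, the first single-place change in this set shows that the group on this aromatic carbon, para to a large group, matters in this assay and that the swap does not leave the read-out unchanged. With hydroxy in place of nitro, the number falls (a 5.1-fold lower number from compound 1 to compound 3 (0.71 log units; beyond the scatter)), a step beyond the scatter, so less of compound 3 is tolerated. Nothing measured here accounts for this fall.

On these data alone, it remains open whether the lower number goes with hydroxy specifically or would also follow from other replacements of nitro, such as an amine, a methoxy group or a carboxylic acid at the same place. A single step also cannot show whether the same swap would have a similar effect at another position on this ring.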